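Extending an Alkyl Chain on Two Related Cores

The source may hold more compounds than are shown below. What is called first, only, known or untested is meant among the compounds shown, and "the series" means these compounds.

Compound 1 `CCc1cn([C@H]2C[C@@H]3OP(=O)(O)OC[C@H]3O2)c(=O)[nH]c1=O` carries an ethyl side chain, and in a functional assay on L1210 cells (Mus musculus) (on this read-out higher numbers stand for weaker inhibition and lower numbers for stronger inhibition), compound 1 gives 55 ug/mL. Compound 3 `CCCc1cn([C@H]2C[C@@H]3OP(=O)(O)OC[C@H]3O2)c(=O)[nH]c1=O` differs from compound 1 by methyl in place of hydrogen on a saturated chain carbon, two bonds along the chain from an aromatic carbon. In this assay compound 3 gives > 500 ug/mL, which is a limit of the assay rather than a number. The step of an at least 9.0-fold higher number from compound 1 to compound 3 (0.95 log units; beyond the scatter) is therefore bounded by the limit of > 500 ug/mL in this assay, at which 2 of the 3 values shown sit. Compound 2 `CCCCc1cn([C@H]2C[C@H](O)[C@@H](CO)O2)c(=O)[nH]c1=O` stands on another core; the difference between the two cores is not broken down here. In this assay compound 2 gives > 500 ug/mL, again a limit of the assay and not a number. Compound 4 `CCCCCc1cn([C@H]2C[C@H](O)[C@@H](CO)O2)c(=O)[nH]c1=O` differs from compound 2 by methyl in place of hydrogen on a saturated chain carbon, four bonds along the chain from an aromatic carbon, the same kind of change as before, but placed four bonds rather than two bonds along the chain from an aromatic carbon. A step that the limit leaves unreadable from compound 2 to compound 4 is expected because compound 2 already sits at the limit of > 500 ug/mL in this assay, at which 2 of the 3 values shown sit. In this assay compound 4 is estimated at 1500 ug/mL, between 400 ug/mL and 6000 ug/mL, most probably reported once more as a limit.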

Compound 4, concentration for 50% inhibition: 476 ug/mL
Compound 4: the middle estimate sits 3.2-fold (0.50 log units) above what was measured; the measured number falls inside the stated range.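

Read in this assay, the same change does not give one matching step on the two cores: the same change on two cores in this assay, an at least 9.0-fold higher number (0.95 log units; beyond the scatter) from compound 1 to compound 3 and an at least 1.0-fold lower number (0.02 log units; that floor lies within the scatter) from compound 2 to compound 4, at least 9.5-fold (0.97 log units) apart, beyond the scatter of two such steps The new step is an at least 1.0-fold lower number from compound 2 to compound 4 (0.02 log units; that floor lies within the scatter), and it is only a floor, as is the earlier step, since each has a limit of the assay at one end: the limit of > 500 ug/mL in this assay, at which 2 of the 4 values shown sit. This does not show that the core alone sets the outcome, since the methyl enters two bonds along the chain in one pair and four bonds along it in the other.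

The compounds shown leave open how one chain, such as butyl, compares on both cores. They also leave open whether a longer chain, such as hexyl, would extend the trend on either core.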